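A few compounds are considered here, and "the series" means these few. Any claim that something is new, unique, unknown or untested is made for them only; others in the source may bear on it.

In a functional assay on T47D cells (Homo sapiens) for inhibition, read by sulforhodamine B assay, with a stated time of 48 h (on this read-out higher numbers stand for weaker inhibition of growth and lower numbers for stronger inhibition of growth), compound 1 `COc1cc(-c2nn(-c3cccc(NC(=O)Nc4ccc(Cl)c(Cl)c4)c3)cc2-c2ccncc2)ccc1Cl` gives > 50000 nM, which is a limit of the assay and not a number. Compound 1 therefore stands at the limit of > 50000 nM in this assay, at which 1 of the 2 values shown sits. In the same assay, compound 2 `O=C(Nc1cccc(-n2cc(-c3ccncc3)c(-c3ccc(Cl)c(O)c3)n2)c1)Nc1ccc(Cl)c(Cl)c1` gives 17900 nM. The measured step of an at least 2.7-fold lower number from compound 1 to compound 2 (0.44 log units; beyond the scatter) lies beyond the scatter, but it concerns hydrogen in place of methyl on an oxygen on an aromatic ring.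

Compound 3 `COc1cc(-c2nn(-c3cccc(NC(=O)c4ccccc4)c3)cc2-c2ccncc2)ccc1Cl` differs from compound 1 elsewhere: phenyl in place of (3,4-dichlorophenyl)amino on a carbonyl carbon. This puts phenyl in place of (3,4-dichlorophenyl)amino on a carbonyl carbon. For the measured compounds named here, no measured step covers that change, so the step above bears on it only loosely, and no large move in this assay is expected. The expected step is small and within the scatter: an at least 1.1-fold lower number from compound 1 to compound 3 (0.04 log units; that floor lies within the scatter). Compound 3 is estimated at 45000 nM, within an expected range of 20000 nM to 50000 nM, and the assay may well report only a limit.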

Compound 3, concentration for total growth inhibition: > 100000 nM
Compound 3 gave a limit, no number; the forecaster's own chance of this, stated with the estimate: 65%; middle value at least 2.2-fold (0.34 log units) away from the limit.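

For the compounds shown here, compound 1 and compound 3 both gave only limits of the assay and not numbers, so no step between them can be read. The compounds shown leave open how far phenyl in place of (3,4-dichlorophenyl)amino on a carbonyl carbon changes growth inhibition.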